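Replacing ethoxycarbonyl with dimethylcarbamoyl on the shared core

The source may hold more compounds than are shown below. What is called first, only, known or untested is meant among the compounds shown, and "the series" means these compounds.

In a functional assay for inhibition, with Homo sapiens as the target (a higher number here means a weaker inhibitor, a lower number a stronger inhibitor), compound 1 (`COC(=O)[C@@H](CC1CCCCC1)Nc1nc2ccccc2o1`) gives 100 nM and compound 2 (`CC(C)c1ccc2oc(NC(CC3CCCCC3)c3ccccc3)nc2c1`) gives 6 nM while compound 3 (`CCOC(=O)c1ccc2oc(NC(CC3CCCCC3)c3ccccc3)nc2c1`) gives 45 nM on the same scale. Compound 3 therefore holds the second highest of the three numbers, lying under compound 1 and over compound 2.

Compound 4 (`CN(C)C(=O)c1ccc2oc(NC(CC3CCCCC3)c3ccccc3)nc2c1`) has not yet been measured. It carries dimethylamino in place of ethoxy on a carbonyl carbon whose other neighbours are aromatic carbon, so that ethoxycarbonyl becomes dimethylcarbamoyl (dimethylamino in place of ethoxy on a carbonyl carbon).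

Within the data shown here, only one measured step bears on this place: the change of isopropyl to ethoxycarbonyl gave a 7.5-fold higher number from compound 2 to compound 3 (0.88 log units; beyond the scatter) in this assay and was modest in size but beyond the scatter. It shows that the number can move with the group at this place. Among the measured compounds shown here, no measured pair, however, compares ethoxy with dimethylamino on a carbonyl carbon, so the size and direction of the new step remain uncertain. A modest rise in the number is tentatively expected, although a step within the scatter remains possible. The estimate implies a 2.0-fold higher number from compound 3 to compound 4 (0.30 log units; within the scatter) as the expected change. The expected value for compound 4 is 90 nM within an estimated range of 25 nM to 350 nM in this assay when it is measured.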

Compound 4, half-maximal inhibitory concentration: 170 nM
Beside the measured number, compound 4's estimate is 1.9-fold (0.28 log units) below it; measured number inside the range.
By their numbers in this assay, from the lowest: compound 2; then compound 3; then compounds 1 and 4 (each within the scatter of the next).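

In this assay the exchange of ethoxy for dimethylamino on a carbonyl carbon gave a 3.8-fold higher number from compound 3 to compound 4 (0.58 log units; beyond the scatter) and so went beyond the scatter, which shows that this place responds to the group on the carbonyl and not only to the swap of isopropyl for a carbonyl-bearing group. The leaving and entering groups each hold 3 heavy atoms, so heavy-atom count alone does not set the number across this pair. Dimethylcarbamoyl in place of isopropyl gave a 28-fold higher number from compound 2 to compound 4 (1.45 log units; beyond the scatter) as a larger step than a 7.5-fold higher number from compound 2 to compound 3 (0.88 log units; beyond the scatter) in the same direction, and among the three groups compared at this place isopropyl keeps the lowest number. No measured evidence accounts for the effect of this change on the number.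

The compounds shown leave open whether a carboxylic acid or an unsubstituted amide at this place would follow the two carbonyl groups or come closer to isopropyl. They also leave open whether a simple alkyl group such as ethyl or tert-butyl would match isopropyl, and so whether the lowest number here belongs to alkyl groups generally.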